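This account rests on a few compounds, and the source may have more. Where it says the series, first, only, none or still open, it means among the compounds named here.

Compound 1 `CC(C)c1ccc(NC(=O)N[C@@H](C)c2ccccc2)cc1` gives 98% in an ADME assay on the whole organism with Oryza sativa as the target, tested at 0.1 uM; on this read-out higher numbers stand for a weaker effect at the one concentration tested and lower numbers for a stronger effect; compound 2 `C[C@H](NC(=O)Nc1ccc(C(F)(F)F)cc1)c1ccccc1` gives 94%; compound 3 `C[C@H](NC(=O)Nc1ccc(F)cc1)c1ccccc1` gives 96%.

Compound 3 stands second highest of these three numbers, and both of its neighbours sit close: a number 2 percentage points lower from compound 1 to compound 3 (within the scatter) and a number 2 percentage points higher from compound 2 to compound 3 (within the scatter). The next compound, compound 4 `C[C@H](NC(=O)Nc1ccc(Br)cc1)c1ccccc1`, differs from compound 3 at one point: bromo in place of fluoro on an aromatic carbon. Every measured step concerns a swap of the group on that same aromatic carbon, and each stayed within the scatter: a number 4 percentage points lower from compound 1 to compound 2 (within the scatter), a number 2 percentage points lower from compound 1 to compound 3 (within the scatter), a number 2 percentage points higher from compound 2 to compound 3 (within the scatter). On that basis no step beyond the scatter is expected in this assay for the new swap, so no change at the digits printed from compound 3 to compound 4 (within the scatter) is the estimated change. Compound 4 is therefore expected to give 96%, with a likely range from 89% to 100%.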

Compound 4, a percentage reported as activity, at one concentration (the size of the read-out at that concentration, not a potency): 98%
For compound 4 the middle estimate is 2 percentage points below the measured one; measured number inside the range.
By their numbers in this assay, from the lowest: compounds 2, 3, 1 and 4 (each within the scatter of the next).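

Bromo on this aromatic carbon, para to a large group, adds a fourth group to the series, and in this assay it also stays within the scatter of the other three: (a number 2 percentage points higher from compound 3 to compound 4 (within the scatter)), (a number 4 percentage points higher from compound 2 to compound 4 (within the scatter)) and (no change at the digits printed from compound 1 to compound 4 (within the scatter)). Isopropyl, trifluoromethyl, fluoro and bromo on this carbon therefore cannot be told apart by this read-out. Nothing at hand offers an explanation for this flat result. The compounds shown leave open whether an amine or a carboxylic acid on this carbon would give a step beyond the scatter.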